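A few compounds are considered here, and "the series" means these few. Any claim that something is new, unique, unknown or untested is made for them only; others in the source may bear on it.

Compound 1 `Nc1nc2cc(Cl)c(Cl)cc2n1Cc1cccc(Cl)c1` and compound 2 `Nc1nc2cc(Cl)c(Cl)cc2n1Cc1cccc(C(F)(F)F)c1` share one core and differ in a single group. In a functional assay on CEM-SS cells (Homo sapiens) for cytotoxicity (a higher number here means a weaker inhibitor, a lower number a stronger inhibitor), compound 1 gives 37000 nM and compound 2 gives 34000 nM. For the measured compounds named here, the one measured step between them is a 1.1-fold lower number from compound 1 to compound 2 (0.04 log units; within the scatter), with trifluoromethyl in place of chloro on an aromatic carbon. Compound 2 therefore stands level with compound 1, and the two values give no sign that this group exchange matters in this assay.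

Compound 3 `Nc1nc2cc(Cl)c(Cl)cc2n1Cc1cc(C(F)(F)F)cc(C(F)(F)F)c1` differs from compound 2 by trifluoromethyl in place of hydrogen on an aromatic carbon, meta to a trifluoromethyl group (trifluoromethyl in place of hydrogen on an aromatic carbon). Going by the values given here, only the step already measured bears on this change, and only loosely: it exchanged one group for another, whereas here a group replaces hydrogen. Among the compounds with values here, no measured pair shows such a replacement, so the expectation remains uncertain. Going by a 1.1-fold lower number from compound 1 to compound 2 (0.04 log units; within the scatter), no step beyond the scatter is expected in this assay, and no direction is favoured. The estimated change is a 1.1-fold lower number from compound 2 to compound 3 (0.05 log units; within the scatter). For compound 3, the expected value is 30000 nM, within an estimated range of 13000 nM to 70000 nM.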

Compound 3, half-maximal inhibitory concentration: 17000 nM
Compound 3: middle estimate off by 1.8-fold (0.25 log units), on the high side; measured number inside the range.
By their numbers in this assay, from the lowest: compounds 3, 2 and 1 (each within the scatter of the next, the first and the last beyond it).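

For the compounds shown here, compound 3 is the first case here in which a group replaces hydrogen on this six-membered aromatic ring, rather than one group being exchanged for another: a second trifluoromethyl, with its 4 heavy atoms, enters on an aromatic carbon, meta to a trifluoromethyl group. In this assay this change gives a 2.0-fold lower number from compound 2 to compound 3 (0.30 log units; within the scatter), so compound 2 and compound 3 count as level, and carrying a second trifluoromethyl at this place produces no difference that can be told apart from the scatter of repeated measurements. Nothing available explains why this replacement leaves the number within the scatter.

The compounds shown leave open whether a very different group on this aromatic carbon, such as an amine or a carboxylic acid, would give a step beyond the scatter in this assay. They also leave open whether trifluoromethyl in place of hydrogen at this spot would give a similar step with chloro, rather than trifluoromethyl, as the group already on the ring.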